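The source may report more compounds than this note shows. Statements on the series, on what has been measured and on what is new or still open speak of the compounds shown alone.

Series notes. Three measured compounds share one core and differ only in the aryl end. Compound 1 `O=C(COc1cccc2ccccc12)N/N=C/c1ccc(O)cc1` gives 60.6 ug/mL in an ADME assay on HEL cells (Homo sapiens) for cytotoxicity; a higher number here means that more compound is tolerated, a lower number that less compound is tolerated. Compound 2 `O=C(COc1cccc2ccccc12)N/N=C/c1cccc([N+](=O)[O-])c1` gives 61.2 ug/mL in this assay, and compound 3 `COc1cc(/C=N/NC(=O)COc2cccc3ccccc23)cc(OC)c1O` gives 52.8 ug/mL in this assay. Compound 1 stands within the scatter of both compound 2 and compound 3: the three numbers do not separate from one another, and none of the aryl variations seen so far has moved this assay beyond what repeated measurements of this kind usually show.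

Compound 4 `O=C(COc1cccc2ccccc12)N/N=C/c1ccc(F)cc1` has not yet been measured. Against compound 1 the change is fluoro in place of hydroxy on an aromatic carbon. Since the aryl variations across compound 1, compound 2 and compound 3 all leave this assay within the scatter, the estimated step of a 1.0-fold lower number from compound 1 to compound 4 (0.02 log units; within the scatter) is expected to stay within the scatter as well, with no direction favoured. Compound 4 is expected to give 58 ug/mL in this assay, with a range from 35 ug/mL to 95 ug/mL.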

Compound 4, half-maximal cytotoxic concentration: 71.6 ug/mL
Compound 4: the middle estimate sits 1.2-fold (0.09 log units) below what was measured; low and high end bracket the measured number.
By their numbers in this assay, from the lowest: compounds 3, 1, 2 and 4 (each within the scatter of the next).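

Fluoro in place of hydroxy on the aromatic carbon para to a large group is the first single-place change in the series, and it gives a 1.2-fold higher number from compound 1 to compound 4 (0.07 log units; within the scatter) in this assay. The hydrogen-bond donor and acceptor counted for hydroxy are therefore not required at this position for the reading to hold, at least in the 4-hydroxyphenyl to 4-fluorophenyl pair. No measurement available here accounts for the two compounds reading alike.

As far as these compounds go, it remains open whether a charged group at this position, such as an amine or a carboxylic acid, or a longer chain would take this assay beyond the scatter. Also open, from the compounds shown here alone, is whether any change to the shared core, rather than to the aryl end, would do so.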